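Pyridinylmethyl swap on the shared core: compound 4

The compounds below may be only part of what the source reports. "The series", "measured", "known", "first", "only" and "open" are said of these compounds alone.

The series shares the core of compound 1 `COc1cccc(CNc2nc(N)c3nc(-c4ccc(C)o4)sc3n2)c1`, which in a functional assay on CHO cells for agonist activity at adenosine receptor A2b (Homo sapiens), read by scintillation counting and cAMP accumulation, with a stated time of 150 min, in the presence of a further agent that is not named here (on this read-out lower numbers stand for stronger inhibition and higher numbers for weaker inhibition), gives 120 nM. Compound 2 `Cc1ccc(-c2nc3c(N)nc(NCc4cccs4)nc3s2)o1` gives 91 nM in this assay, and the step of a 1.3-fold lower number from compound 1 to compound 2 (0.12 log units; within the scatter). Compound 3 `Nc1nc(NCc2ccncc2)nc2sc(-c3ccco3)nc12` gives 33 nM in this assay, the lowest of the three numbers; the values of compound 2 and compound 1 both lie beyond the scatter above it, so compound 3 is the strongest inhibitor among the measured compounds.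

Compound 4 `Nc1nc(NCc2ccccn2)nc2sc(-c3ccco3)nc12` differs from compound 3 only in pyridin-2-yl in place of pyridin-4-yl on a saturated chain carbon bound to a nitrogen on an aromatic ring. For the measured compounds named here, no measured pair shows this exchange. Going by the values given here, the single recorded step, a 1.3-fold lower number from compound 1 to compound 2 (0.12 log units; within the scatter), concerns a different group at the same place and stayed within the scatter, so it bears only loosely on the present case. Among the compounds with values here, with no direct precedent, the step is expected to be modest: a 1.4-fold higher number from compound 3 to compound 4 (0.13 log units; within the scatter). Compound 4 is accordingly estimated at 45 nM in this assay, with a range of 15 nM to 150 nM.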

Compound 4, half-maximal inhibitory concentration: 95 nM
Compound 4: middle estimate off by 2.1-fold (0.32 log units), on the low side, within the range that was stated.
By their numbers in this assay, from the lowest: compound 3; then compounds 2, 4 and 1 (each within the scatter of the next).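

In this assay, for the compounds shown here, the place on a saturated chain carbon bound to a nitrogen on an aromatic ring now shows a step beyond the scatter, a 2.9-fold higher number from compound 3 to compound 4 (0.46 log units; beyond the scatter), whereas the only earlier step at this place stayed within it. Pyridin-4-yl and pyridin-2-yl have the same atoms and the same counted features, so the read-out at this place distinguishes two groups that differ only in how those atoms are joined. No measurement on hand accounts for this difference.

Pyridin-3-yl at this place remains open, as does a longer chain carrying pyridin-4-yl. Compounds 1 and 2 differ from compound 3 in more than one place, so the standing of pyridin-4-yl against 3-methoxyphenyl or thiophen-2-yl also remains unresolved.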